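Extending the chain of compound 2 by four carbons

The source may hold more compounds than are shown below. What is called first, only, known or untested is meant among the compounds shown, and "the series" means these compounds.

Compound 2 `CCCCCCCCCCCCCCNC(=O)[C@@H](NC(=O)c1cc2ccccc2n1C)[C@@H](C)O` gives the lowest number among the three measured compounds in a functional assay on SW-620 cells (Homo sapiens) for cytotoxicity, read by MTT assay, with a stated time of 48 h (on this read-out lower numbers stand for stronger inhibition and higher numbers for weaker inhibition), at 21500 nM, though its gap to compound 1 `CCCCCCCCCCCCCCNC(=O)[C@@H](NC(=O)c1cc2ccccc2o1)[C@@H](C)O` at 26700 nM, seen as a 1.2-fold lower number from compound 1 to compound 2 (0.09 log units; within the scatter), lies within the scatter. Compound 3 `C/C=C/C=C/C(=O)N[C@H](C(=O)NCCCCCCCCCCCCCC)[C@@H](C)O` gives 200000 nM, a step of a 9.3-fold higher number from compound 2 to compound 3 (0.97 log units; beyond the scatter). Compound 4 `CCCCCCCCCCCCCCCCCCNC(=O)[C@@H](NC(=O)c1cc2ccccc2n1C)[C@@H](C)O` differs from compound 2 by butyl in place of hydrogen on a saturated chain carbon, ten or more bonds along the chain from an amide-type nitrogen. For the measured compounds named here, no measured step touches this chain: all three steps, including a 7.5-fold higher number from compound 1 to compound 3 (0.87 log units; beyond the scatter), change the group on the carbonyl carbon instead. With nothing to go on beyond compound 2 itself, no step beyond the scatter is expected; the estimated step is a 1.2-fold higher number from compound 2 to compound 4 (0.07 log units; within the scatter). Compound 4 is therefore expected to give about 25000 nM in this assay, within a range of 8000 nM to 80000 nM.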

Compound 4, half-maximal inhibitory concentration: 124000 nM
The estimate for compound 4 lay 5.0-fold (0.70 log units) below the measured number, outside the stated range (above it).
By their numbers in this assay, from the lowest: compounds 2 and 1 (each within the scatter of the next); then compounds 4 and 3 (each within the scatter of the next).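

The earlier steps shown here changed only the group on the carbonyl carbon, so they said nothing about the chain. In this assay, butyl in place of hydrogen on a saturated chain carbon, ten or more bonds along the chain from an amide-type nitrogen, gives a 5.8-fold higher number from compound 2 to compound 4 (0.76 log units; beyond the scatter), so even this distant place on the chain affects the result, with the longer chain giving weaker inhibition. Nothing available gives a reason for this step.

As far as these compounds go, the effect of a shorter chain remains open, as does that of an amine or a carboxylic acid at this place on the chain.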